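This account rests on a few compounds, and the source may have more. Where it says the series, first, only, none or still open, it means among the compounds named here.

In a functional assay on Jurkat cells (Homo sapiens) for antiproliferative activity, read by WST assay, with a stated time of 72 h (on this read-out lower numbers stand for stronger inhibition and higher numbers for weaker inhibition), compound 1 `c1ccc(-c2noc(-c3cc4ccccc4[nH]3)n2)cc1` reaches only a limit of the assay, > 50000 nM. Compound 2 `Clc1ccc(-c2noc(-c3cc4ccccc4[nH]3)n2)cc1` likewise stops at a limit in this assay, > 50000 nM. Among the compounds with values here, compound 2 thus stands at the same limit as the only other measured compound, and the step that the two limits leave unreadable from compound 1 to compound 2 cannot be sized, since both values sit at the limit of > 50000 nM in this assay, at which 2 of the 2 values shown sit. Compound 3 `COc1ccc(-c2noc(-c3cc4ccccc4[nH]3)n2)cc1` differs from compound 2 by methoxy in place of chloro on an aromatic carbon. Within the data shown here, no measured step bears on this change, and the single step that exists between the measured compounds is itself unreadable, so there is no ground to expect a shift beyond the scatter of this assay. The step that the limit leaves unreadable from compound 2 to compound 3 is therefore expected to be small, with compound 3 most likely remaining at the limit. Compound 3 is estimated at 60000 nM in this assay, with a range from 20000 nM to 200000 nM.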

Compound 3, half-maximal inhibitory concentration: > 50000 nM
Compound 3: no number, only a limit; the forecaster's own chance of this, stated with the estimate: 80%; the middle value lies beyond the limit too.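

No step can be read between compound 1, compound 2 and compound 3, since all three stop at the same limit in this assay: the limit of > 50000 nM in this assay, at which 3 of the 3 values shown sit. The compounds shown leave open how strongly any of the three inhibits, and whether hydrogen, chloro or methoxy on that aromatic carbon makes any difference.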